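Swapping Isopropyl for Oxolanyl: Expected Solubility Shift

A few compounds are considered here, and "the series" means these few. Any claim that something is new, unique, unknown or untested is made for them only; others in the source may bear on it.

Compound 2 `Cc1cc(C)c(CN2CCc3ccc(OC(C)C)c(Cl)c3C2=O)c(=O)[nH]1` sits lowest of the two compounds measured in a physicochemical assay for solubility, measured as kinetic solubility (a higher number here means a more soluble compound, a lower number a less soluble compound), where compound 2 gives 19600 nM. Compound 1 `Cc1cc(C)c(CN2CCc3c(Cl)cc(-c4c(C)noc4C)c(Cl)c3C2=O)c(=O)[nH]1` gives 93500 nM in this assay, a higher number that lies beyond the scatter. Compound 3 `Cc1cc(C)c(CN2CCc3ccc(O[C@@H]4CCOC4)c(Cl)c3C2=O)c(=O)[nH]1` differs from compound 2 in one place: oxolan-3-yl in place of isopropyl on an oxygen on an aromatic ring. The solubility of compound 3 is estimated at 45000 nM, within a range of 18000 nM to 110000 nM. This expectation amounts to a rise of a 2.3-fold higher number from compound 2 to compound 3 (0.36 log units; beyond the scatter), a modest step that may be only just beyond the scatter.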

Compound 3, solubility: 510000 nM
Compound 3: middle estimate off by 11-fold (1.05 log units), on the low side, outside the stated range (above it).
By their numbers in this assay, from the lowest: compound 2; then compound 1; then compound 3.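

In this assay, replacing isopropyl with oxolan-3-yl on an oxygen on an aromatic ring gives a 26-fold higher number from compound 2 to compound 3 (1.42 log units; beyond the scatter), a large step. Within the data shown here, the two earlier compounds differ in more than one place, so only this pair shows that a change at this position alone can move the read-out so far. Nothing available explains the size of the step.

The entering group brings a ring, a ring oxygen and a defined stereocentre together, so their shares remain unseparated. Cyclopentyl on the same oxygen, or the opposite stereoisomer of oxolan-3-yl, would help to tell them apart.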